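The source may report more compounds than this note shows. Statements on the series, on what has been measured and on what is new or still open speak of the compounds shown alone.

In a functional assay on CCRF-CEM cells (Homo sapiens), read by MTT assay, with a stated time of 72 h (a higher number here means a weaker inhibitor, a lower number a stronger inhibitor), compound 1 `CSc1ncnc2c1c(-c1ccsc1)cn2[C@@H]1O[C@H](CO)[C@@H](O)[C@H]1O` reaches only a limit, > 20000 nM. Compound 2 `C#Cc1cn([C@@H]2O[C@H](CO)[C@@H](O)[C@H]2O)c2ncnc(SC)c12` also reaches only a limit, > 20000 nM. Compound 2 therefore has no number of its own, and both results sit at the limit of > 20000 nM in this assay, at which 2 of the 2 values shown sit. Going by the values given here, the only measured change, a step that the two limits leave unreadable from compound 1 to compound 2, gives no size to carry forward. Compound 3 `C#Cc1cn([C@@H]2O[C@H](CO)[C@@H](O)[C@H]2O)c2ncnc(C)c12` keeps the ethynyl group of compound 2 but has methyl in place of methylsulfanyl on an aromatic carbon, next to the ring nitrogen: methyl in place of methylsulfanyl on an aromatic carbon. Among the compounds with values here, no measured step involves this change, so the data offer no firm direction, and the cautious expectation is little or no gain in this assay. For compound 3 the expected value is 12000 nM, with an estimated range from 2000 nM to 20000 nM. The expected change is an at least 1.6-fold lower number from compound 2 to compound 3 (0.22 log units; that floor lies within the scatter).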

Compound 3, half-maximal inhibitory concentration: 5600 nM
The estimate for compound 3 lay 2.1-fold (0.33 log units) above the measured number, within the range that was stated.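

In this assay, methyl in place of methylsulfanyl on the aromatic carbon next to the ring nitrogen gives an at least 3.5-fold lower number from compound 2 to compound 3 (0.55 log units; beyond the scatter), so this change lowers the number by more than the usual scatter. Compound 3 thus gives the series its first real number, and the earlier pair could not offer that, with compound 1 and compound 2 both stopping at a limit: the limit of > 20000 nM in this assay, at which 2 of the 3 values shown sit. The printed size is only a floor, and the true step may be larger.

The compounds shown leave open whether an amine or a methoxy group at this same place would lower the number further or lose the gain. They also leave open whether methyl would give a similar step with thiophen-3-yl in place of ethynyl.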